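A few compounds are considered here, and "the series" means these few. Any claim that something is new, unique, unknown or untested is made for them only; others in the source may bear on it.

Compound 1 `CC(=O)c1sc(NNS(=O)(=O)c2ccc(C)cc2)nc1C` gives 8770 nM in a functional assay on HepG2 cells (Homo sapiens) for inhibition, read by XTT assay, with a stated time of 72 h; a higher number here means a weaker inhibitor, a lower number a stronger inhibitor. Compound 2 `CCOC(=O)c1sc(NNS(=O)(=O)c2ccc(C)cc2)nc1C` is reported only as a limit, < 4510 nM, which is the limit of < 4510 nM in this assay, at which 1 of the 3 values shown sits. The change ethoxy in place of methyl on a carbonyl carbon therefore gives an at least 1.9-fold lower number from compound 1 to compound 2 (0.28 log units; that floor lies within the scatter). Compound 3 `CC(=O)c1sc(N(C(C)=O)N(C(C)=O)S(=O)(=O)c2ccc(C)cc2)nc1C` gives 57400 nM in this assay, a higher number than compound 1, beyond the scatter; the difference between the core of compound 3 and that of compound 1 is not broken down here. Compound 4 `CCOC(=O)c1sc(N(C(C)=O)N(C(C)=O)S(=O)(=O)c2ccc(C)cc2)nc1C` carries the same change against compound 3, (ethoxy in place of methyl on a carbonyl carbon), at a place described in the same words as for compound 1 and compound 2. Compound 4 is expected to follow the earlier step, a 1.9-fold lower number from compound 3 to compound 4 (0.28 log units; within the scatter), resting on an at least 1.9-fold lower number from compound 1 to compound 2 (0.28 log units; that floor lies within the scatter). The estimate for compound 4 in this assay is 30000 nM, between 10000 nM and 80000 nM.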

Compound 4, half-maximal inhibitory concentration: > 56900 nM
Compound 4: a limit, no number (the forecaster's own chance of this, stated with the estimate: 10%); at least 1.8-fold (0.27 log units) between middle value and limit.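

Compound 4 gives > 56900 nM in this assay, which is a limit, so the step from compound 3 to compound 4 cannot be read. The compounds shown leave open how ethoxy in place of methyl on a carbonyl carbon acts on the core of compound 3.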